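This account rests on a few compounds, and the source may have more. Where it says the series, first, only, none or still open, it means among the compounds named here.

Measured so far in a functional assay on KB cells (Homo sapiens) for inhibition, read by MTT assay, with a stated time of 24 h, tested at 0.1 ug/mL; on this read-out lower numbers stand for less inhibition of growth and higher numbers for more inhibition of growth at the one concentration tested:
Compound 1 (`O=C(O)CCCCC(CCSC(=O)c1ccccc1)SC(=O)c1ccccc1`) gives ("not active" (no number reported))
Compound 2 (`O=C(CCCCC1CCSS1)NO`) gives (7.92%)
Compound 3 (`O=C(CCCCC1CCSS1)Nc1ccccn1`) gives ("not active" (no number reported))

Compound 3 has no single number and is reported as ("not active" (no number reported)). Compound 1 shares that report ("not active" (no number reported)), and only compound 2 carries a number (7.92%).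

Compound 4 (`O=C(CCCCC1CCSS1)Nc1ccc(Cl)cn1`) has not yet been measured. It differs from compound 3 by one change (chloro in place of hydrogen on an aromatic carbon), chloro in place of hydrogen on an aromatic carbon. For the measured compounds named here, no measured pair in this assay shows the effect of such a change. Going by the values given here, a small upward step is expected, probably none beyond the scatter, since compound 3 starts from ("not active" (no number reported)) and the sole number, for compound 2, is low (7.92%).

For compound 4 the estimated value is (5%), with an expected range from (0%) to (15%).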

Compound 4, percent growth inhibition at one concentration: "not active" (no number reported)
Nothing numeric was reported for compound 4, and the estimate cannot be compared.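

In this assay compound 3 ("not active" (no number reported)) and compound 4 ("not active" (no number reported)) carry no numbers, so no step can be read between them. No measurement shown offers an explanation. As far as these compounds go, whether chloro in place of hydrogen changes growth inhibition stays open.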